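Halogen swap on the salicylanilide-type series: bromo to chloro

This account rests on a few compounds, and the source may have more. Where it says the series, first, only, none or still open, it means among the compounds named here.

Measured so far in a functional assay on HL-60 cells (Homo sapiens) for cytotoxicity, read by luminescence and CellTiter-Glo, with a stated time of 3 days; on this read-out higher numbers stand for weaker inhibition and lower numbers for stronger inhibition:
compound 1 `O=C(Nc1ccc(C(F)(F)F)cc1)c1ccc(Cl)cc1O` gives 630 nM
compound 2 `O=C(Nc1ccc(C(F)(F)F)cc1)c1ccc(Br)cc1O` gives 360 nM
compound 3 `N#Cc1ccc(NC(=O)c2cc(Br)c(-c3ccccc3)cc2O)cc1` gives 700 nM

The three values sit close together. Within the data shown here, the step of a 1.8-fold higher number from compound 2 to compound 1 (0.24 log units; within the scatter) is the one clean comparison: compound 1 differs from compound 2 by chloro in place of bromo on an aromatic carbon. Compound 3 carries a different core; the difference between the core of compound 3 and the core of compound 2 is not broken down here. Compound 3 and compound 1 lie within the scatter of each other, as do compound 3 and compound 2, so no order among the three can be read from this assay.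

Compound 4 `N#Cc1ccc(NC(=O)c2cc(Cl)c(-c3ccccc3)cc2O)cc1` is not yet measured. It differs from compound 3 by chloro in place of bromo on an aromatic carbon. This is the same kind of change as from compound 2 to compound 1, but not the same: in compound 1 the chloro stands meta to a hydroxy group and para to a large group, whereas in compound 4 it stands ortho to a phenyl group, meta to a large group and para to a hydroxy group.

Among the measured compounds shown here, the expected step in this assay is a 1.4-fold higher number from compound 3 to compound 4 (0.15 log units; within the scatter), beside the measured 1.8-fold higher number from compound 2 to compound 1 (0.24 log units; within the scatter), because a 1.8-fold higher number from compound 2 to compound 1 (0.24 log units; within the scatter) is the only guide the data give for this change. For compound 4 the expected value is 1000 nM, with a likely range from 450 nM to 2200 nM.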

Compound 4, half-maximal inhibitory concentration: 520 nM
Compound 4: middle estimate off by 1.9-fold (0.28 log units), on the high side; the measured number falls inside the stated range.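

In this assay, chloro in place of bromo on an aromatic carbon of the core of compound 3 gives a 1.3-fold lower number from compound 3 to compound 4 (0.13 log units; within the scatter). Set beside the earlier case on the other core, the two steps do not differ by more than the scatter of two such steps allows: the same change on two cores in this assay, a 1.8-fold higher number (0.24 log units; within the scatter) from compound 2 to compound 1 and a 1.3-fold lower number (0.13 log units; within the scatter) from compound 3 to compound 4, 2.4-fold (0.37 log units) apart, within the scatter of two such steps. On these two pairs, the swap stays within the scatter on both cores, so the exchange of bromo for chloro can be carried from one core to the other without a readable shift in this read-out, but this does not show that the two cores respond alike, since two pairs with the halogen in different surroundings cannot reveal a small real effect of either sign.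

The compounds shown hold only bromo or chloro at this place, so it remains open whether fluoro, a methoxy group, an amine or a carboxylic acid there would give a step beyond the scatter. They also never set trifluoromethyl and nitrile on an otherwise shared core, and the phenyl group appears only alongside nitrile, so the contribution of each of these groups remains unresolved.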